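A few compounds are considered here, and "the series" means these few. Any claim that something is new, unique, unknown or untested is made for them only; others in the source may bear on it.

In a functional assay on HT-29 cells (Homo sapiens) for antiproliferative activity, read by MTT assay, with a stated time of 24 h (a higher number here means a weaker inhibitor, a lower number a stronger inhibitor), compound 1 `COc1ccc(C(=O)/C=C/c2ccc(-c3ccccc3)cc2)c2c1C=CC(C)(C)O2` gives > 10000 nM, which is a limit of the assay and not a number. Compound 2 `COc1ccc(C(=O)/C=C/c2ccc(-n3ccnc3)cc2)c2c1C=CC(C)(C)O2` gives > 6600 nM, again a limit. Going by the values given here, compound 3 `COc1ccc(C(=O)/C=C/c2ccc([N+](=O)[O-])cc2)c2c1C=CC(C)(C)O2` gives 3730 nM, the only actual number of the three.

Compound 4 `COc1ccc(C(=O)/C=C/c2ccc(C(F)(F)F)cc2)c2c1C=CC(C)(C)O2` has not yet been measured. It differs from compound 3 by trifluoromethyl in place of nitro on an aromatic carbon, with trifluoromethyl in place of nitro on an aromatic carbon, para to a large group.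

Among the compounds with values here, the steps that bear on this change are those at the same position that end on nitro. Nitro in place of phenyl gives an at least 2.6-fold lower number from compound 1 to compound 3 (0.42 log units; beyond the scatter), and nitro in place of 1H-imidazol-1-yl gives an at least 1.7-fold lower number from compound 2 to compound 3 (0.24 log units; that floor lies within the scatter). Between the two compounds without nitro, the measurements give a step that the two limits leave unreadable from compound 1 to compound 2. Within the data shown here, no measured step involves trifluoromethyl, so these steps offer only a rough guide. Both compounds that lack the nitro group stand at limits, so a modest move towards a higher number is expected, and compound 4 may also end at a limit. In this assay the expected change is a 1.6-fold higher number from compound 3 to compound 4 (0.21 log units; within the scatter). For compound 4 the estimate is 6000 nM, with an expected range from 2500 nM to 14000 nM.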

Compound 4, half-maximal inhibitory concentration: > 10000 nM
Compound 4: a limit, no number (the forecaster's own chance of this, stated with the estimate: 40%); middle value at least 1.6-fold (0.22 log units) from the limit.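

In this assay, trifluoromethyl in place of nitro on an aromatic carbon, para to a large group, gives an at least 2.6-fold higher number from compound 3 to compound 4 (0.42 log units; beyond the scatter), and this size is only a floor set by a limit of the assay. Going by these compounds alone, this gives the first step at this position that ends on trifluoromethyl and can be read, and it lies beyond the scatter. The steps to compound 4 from compound 1 and from compound 2 join two limits and cannot be read, so of the four groups shown here only nitro gives an actual number, while the others stand at limits, the highest of them shared: the limit of > 10000 nM in this assay, at which 2 of the 4 values shown sit.

The compounds shown leave open how far past its limit compound 4 lies, and with it the full size of this step. They also leave open whether a group such as an amine, a carboxylic acid or a nitrile at the same place would give a number close to that of compound 3 or would stay at a limit. Compound 3 itself gives 3730 nM.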